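The compounds below may be only part of what the source reports. "The series", "measured", "known", "first", "only" and "open" are said of these compounds alone.

Compound 1 `CNc1nc2c(Cl)cc(Cl)cc2n1COCCO`: in a functional assay on KB cells (Homo sapiens) for inhibition (on this read-out lower numbers stand for stronger inhibition and higher numbers for weaker inhibition), compound 1 gives > 100000 nM, which is a limit of the assay and not a number.
Compound 2 `OCCOCn1c(SCc2ccccc2)nc2c(Cl)cc(Cl)cc21`: in this assay compound 2 gives > 100000 nM, again a limit of the assay.
Compound 3 `CNc1nc2c(Cl)c(Cl)ccc2n1COCCO`: in this assay compound 3 gives > 100000 nM, also a limit of the assay.

Compounds 1 and 2 share a core and differ in one place: benzylsulfanyl in place of methylamino on an aromatic carbon. The step between them, a step that the two limits leave unreadable from compound 1 to compound 2, cannot be read in size because both compounds sit at the limit of > 100000 nM in this assay, at which 3 of the 3 values shown sit; all that the two values show is that neither compound inhibits within the range the assay can report.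

Compound 3 is built from the same atoms as compound 1, joined differently; the difference between the two cores is not broken down here. Compound 4 `OCCOCn1c(SCc2ccccc2)nc2c(Cl)c(Cl)ccc21` carries the core of compound 3 and differs from it in one place: benzylsulfanyl in place of methylamino on an aromatic carbon. The place of this change is described in the same words as for the pair of compound 1 and compound 2, so it is the same change made on the second core.

For compound 4 the step that the limit leaves unreadable from compound 3 to compound 4 is an expectation only, resting on the fact that compound 3 gives > 100000 nM and that the same change left compound 2 at > 100000 nM. Compound 4 is therefore expected to sit around 200000 nM, with a plausible range from 50000 nM to 1000000 nM, and most likely the assay will again report only a limit for compound 4.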

Compound 4, half-maximal inhibitory concentration: 35000 nM
Compound 4: the middle estimate sits 5.7-fold (0.76 log units) above what was measured; the measured number lies below the stated range.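

In this assay, from the compounds shown here alone, putting benzylsulfanyl in place of methylamino on the core of compound 3 gives an at least 2.8-fold lower number from compound 3 to compound 4 (0.45 log units; beyond the scatter), so on this core the change brings a measurable inhibition into the range the assay can report, though the true size of the step remains open since compound 3 stands at a limit. The same change on the core of compound 1 leads to compound 2. Compound 2 gives > 100000 nM, which is a limit of the assay and not a number. The step on the core of compound 1 cannot be read, so the change is not shown to carry over from one core to the other, nor is it shown to differ in size between them, and the only thing the values offer on this is how many of them cannot be read: the limit of > 100000 nM in this assay, at which 3 of the 4 values shown sit.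

The compounds shown leave open which part of benzylsulfanyl goes with the lower number on the core of compound 3, the sulfur or the benzene ring, and a benzylamino group or a methylsulfanyl group on the same aromatic carbon would separate the two. They also leave open whether a longer chain in place of the (2-hydroxyethoxy)methyl group would change the number for compound 4.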